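Amide nitrogen methylation on a second core: solubility notes

The compounds below may be only part of what the source reports. "The series", "measured", "known", "first", "only" and "open" are said of these compounds alone.

Measured so far in a physicochemical assay for solubility, read by LC-MS, in phosphate buffer, with a stated time of 24 h, at pH 7.4; a higher number here means a more soluble compound, a lower number a less soluble compound:
compound 1 `CN(C)C(=O)c1cc(-c2cnc(NCc3c(F)ccc4c3CCO4)c3cn[nH]c(=O)c23)n(C)n1` — compound 1 gives 3000 nM
compound 2 `CNC(=O)c1cc(-c2cnc(NCc3c(F)ccc4c3CCO4)c3cn[nH]c(=O)c23)n(C)n1` — compound 2 gives 7000 nM
compound 3 `CNC(=O)c1ccc(-c2cnc(NCc3c(F)ccc4c3CCO4)c3cn[nH]c(=O)c23)c(C)n1` — compound 3 gives 19000 nM

Compound 3 stands highest of the three; its nearest neighbour is compound 2, and the step between them in this assay is a 2.7-fold higher number from compound 2 to compound 3 (0.43 log units; beyond the scatter). The structural difference behind that step is 2-methyl-6-(methylcarbamoyl)pyridin-3-yl in place of 1-methyl-3-(methylcarbamoyl)-1H-pyrazol-5-yl on an aromatic carbon. Against compound 1 the gap is wider, a 6.3-fold higher number from compound 1 to compound 3 (0.80 log units; beyond the scatter).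

Within the pyrazole pair, the change methyl in place of hydrogen on an amide-type nitrogen gave a 2.3-fold lower number from compound 2 to compound 1 (0.37 log units; beyond the scatter).

Compound 4 `Cc1nc(C(=O)N(C)C)ccc1-c1cnc(NCc2c(F)ccc3c2CCO3)c2cn[nH]c(=O)c12` is not yet measured in this assay. It differs from compound 3 by methyl in place of hydrogen on an amide-type nitrogen. Among the compounds with values here, the place line reads the same, word for word, as the one for the change from compound 2 to compound 1, so this is the same change, now made on the core of compound 3 rather than that of compound 2. Within the data shown here, the only precedent is the step from compound 2 to compound 1, where methyl in place of hydrogen on an amide-type nitrogen gave a 2.3-fold lower number from compound 2 to compound 1 (0.37 log units; beyond the scatter). Whether the same move carries over to a different core is not known from these three compounds alone.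

Among the measured compounds shown here, the expectation for compound 4 is a step of about a 2.2-fold lower number from compound 3 to compound 4 (0.35 log units; beyond the scatter), resting on the single precedent a 2.3-fold lower number from compound 2 to compound 1 (0.37 log units; beyond the scatter) applied to compound 3 and its value 19000 nM. The estimate for compound 4 in this assay is 8500 nM, with a range from 3000 nM to 20000 nM to allow for the change behaving differently on this core.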

Compound 4, solubility: 403000 nM
Beside the measured number, compound 4's estimate is 47-fold (1.68 log units) below it; measured number outside the range, above it.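

In this assay, methyl in place of hydrogen on an amide-type nitrogen gives a 21-fold higher number from compound 3 to compound 4 (1.33 log units; beyond the scatter), while the same change on the core of compound 2 gave a 2.3-fold lower number from compound 2 to compound 1 (0.37 log units; beyond the scatter), so the direction of this change did not carry over from one core to the other, and the new step is also the larger of the two. Within the data shown here, this shows that the effect of the change depends on the rest of the molecule, and that a step measured on one core is a poor guide to the step on another; it does not show which of the two results is the more typical, since the comparison rests on only two matched pairs and one reading for each compound. Nothing measured here bears on why the two cores part ways.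

Still open, from the compounds shown here alone, is whether the high number of compound 4 is particular to the dimethylcarbamoyl group or extends to other amides on the same core, such as one carrying an ethyl group, a longer chain or a cyclic amine such as azetidine. Also open, going by these compounds, is how the primary carboxamide or the carboxylic acid would compare on each of the two cores, which would show whether the split between them persists beyond this single methyl change.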